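The source may report more compounds than this note shows. Statements on the series, on what has been measured and on what is new or still open speak of the compounds shown alone.

Measured so far:

compound 1, `CCCCN(c1nc2c(NC(C)=O)cccc2o1)[C@H](C)c1ccc(-c2ccccc2-c2nnn[nH]2)cc1`: 2.2 h
compound 2, `C[C@H](c1ccc(-c2ccccc2-c2nc(=O)o[nH]2)cc1)N(CC1CC1)c1nc2c(C(=O)O)cccc2o1`: 2.6 h
compound 3, `CCCCN(c1nc2c(C(=O)NS(C)(=O)=O)cccc2o1)[C@H](C)c1ccc(-c2ccccc2-c2nnn[nH]2)cc1`: 2.7 h

In an ADME assay on the whole organism (Macaca fascicularis) for metabolic stability, read by LC-MS, using cassette dosing, at a dose of 1 mg/kg by the oral route (on this read-out higher numbers stand for a longer-lived compound and lower numbers for a shorter-lived compound), compound 1 gives 2.2 h, the lowest of the three numbers, though the gaps to compound 2 and to compound 3 are both within the scatter, so the three compounds cannot be told apart on this read-out. Among the measured compounds shown here, the one step measured at a single place is a 1.2-fold higher number from compound 1 to compound 3 (0.09 log units; within the scatter), which also falls within the scatter.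

Compound 4, `CCCCN(c1nc2c(-c3ccccn3)cccc2o1)[C@H](C)c1ccc(-c2ccccc2-c2nnn[nH]2)cc1`, differs from compound 1 at the same aromatic carbon of the shared core: pyridin-2-yl in place of acetamido on an aromatic carbon. For the measured compounds named here, no measured pair carries this exchange; the only step that bears on it is the one from compound 1 to compound 3, at the same site, and that step is within the scatter. Nothing among the three measured compounds therefore points to a step beyond the scatter in either direction. The expected step is a 1.1-fold higher number from compound 1 to compound 4 (0.04 log units; within the scatter), that is, essentially none. For compound 4 the estimate in this assay is 2.4 h, with a range of 1.2 h to 4.8 h.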

Compound 4, half-life: 5.9 h
Compound 4: middle estimate off by 2.5-fold (0.39 log units), on the low side, and the stated range ends below it.
By their numbers in this assay, from the lowest: compounds 1, 2 and 3 (each within the scatter of the next); then compound 4.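

In this assay, the group on this aromatic carbon of the shared core now gives steps beyond the scatter: pyridin-2-yl in place of acetamido gives a 2.7-fold higher number from compound 1 to compound 4 (0.43 log units; beyond the scatter), and pyridin-2-yl in place of (methylsulfonyl)carbamoyl gives a 2.2-fold higher number from compound 3 to compound 4 (0.34 log units; beyond the scatter). Among the compounds shown here, the one earlier step at this carbon lay within the scatter, so the read-out is now seen to depend on the group held here, with an aromatic ring as the entering group giving the higher number in both steps. No measurement on hand gives a reason for either step.

As far as these compounds go, it remains open whether phenyl, which lacks the ring nitrogen of pyridin-2-yl, would give a similar step. From the compounds shown here alone, it also remains open whether a saturated ring such as piperidin-1-yl at this carbon would do the same.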